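A few compounds are considered here, and "the series" means these few. Any claim that something is new, unique, unknown or untested is made for them only; others in the source may bear on it.

Of the compounds shown here, three sharing one core have been measured in a functional assay on HEK293 cells for agonist activity at G-protein coupled receptor 39 (Homo sapiens), read by scintillation proximity assay and inositol phosphate accumulation, with a stated time of 75 min, in the presence of a further agent that is not named here; on this read-out higher numbers stand for an effect only at larger amounts of compound and lower numbers for an effect already at smaller amounts. Compound 1 `Cc1nn(-c2ncnc3nc[nH]c23)c2c1C(OCC(=O)c1ccc(F)cc1)CC(=O)N2` gives 3 nM, compound 2 `Cc1nn(-c2ncnc3nc[nH]c23)c2c1C(OC1CCCC1)CC(=O)N2` gives 2 nM, and compound 3 `Cc1cc(C)n(CCOC2CC(=O)Nc3c2c(C)nn3-c2ncnc3nc[nH]c23)n1` gives 16 nM, the highest number of the three. Compound 4 `CCCCCCCCOC1CC(=O)Nc2c1c(C)nn2-c1ncnc2nc[nH]c12` differs from compound 3 in one place: hexyl in place of 3,5-dimethyl-1H-pyrazol-1-yl on a saturated chain carbon, two bonds along the chain from an oxygen on a saturated carbon. Within the data shown here, two measured steps bear on this change: an 8.0-fold higher number from compound 2 to compound 3 (0.90 log units; beyond the scatter) and a 5.3-fold higher number from compound 1 to compound 3 (0.73 log units; beyond the scatter), both of which lead toward compound 3 as groups without the pyrazole are exchanged for the pyrazole-bearing chain. Compound 4 carries a plain chain instead, so a move back toward lower numbers is expected, of a size a 2.7-fold lower number from compound 3 to compound 4 (0.43 log units; beyond the scatter). Compound 4 is therefore estimated at 6 nM, within a range from 1.5 nM to 25 nM.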

Compound 4, half-maximal effective concentration: 8 nM
Beside the measured number, compound 4's estimate is 1.3-fold (0.12 log units) below it; measured number inside the range.
By their numbers in this assay, from the lowest: compounds 2 and 1 (each within the scatter of the next); then compounds 4 and 3 (each within the scatter of the next).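

On the chain carbon two bonds along from the oxygen, a ring is not needed to keep this activity: hexyl, with no ring and no hydrogen-bond acceptors, gives a 2.0-fold lower number from compound 3 to compound 4 (0.30 log units; within the scatter) in this assay. The plain chain still stands apart from the two other groups on the oxygen, with a 4.0-fold higher number from compound 2 to compound 4 (0.60 log units; beyond the scatter) and a 2.7-fold higher number from compound 1 to compound 4 (0.43 log units; beyond the scatter). No available evidence explains these steps. From the compounds shown here alone, it remains open how a shorter chain such as butyl would read here, or a hexyl chain ending in an amine or a carboxylic acid.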